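This account rests on a few compounds, and the source may have more. Where it says the series, first, only, none or still open, it means among the compounds named here.

Of the compounds shown here, three sharing a common core have been tested in an assay on CHO cells for displacement of a labelled ligand from C-X-C chemokine receptor type 3 (Homo sapiens), with a stated time of 60 min; on this read-out lower numbers stand for stronger inhibition and higher numbers for weaker inhibition. Compound 1 `Cc1cc(CN(CCC(F)(F)F)C(CC(=O)O)c2ccc(Cl)cc2)ccc1OCCN1C(=O)CCC1=O` gives 650 nM. Compound 2 `CCCCN(Cc1ccc(OCCn2c(=O)ccn(C)c2=O)c(OC)c1)C(CC(=O)O)c1ccc(Cl)cc1` gives 69 nM. Compound 3 `COc1cc(CN(CC(C)C)C(CC(=O)O)c2ccc(Cl)cc2)ccc1OCCN1C(=O)CCC1=O` gives 34 nM, the lowest of the three numbers; its gap to compound 2 is the smaller of the two and lies just beyond the usual scatter of repeated measurements, while its gap to compound 1 lies far beyond it.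

Compound 4 `COc1cc(CN(CC(C)C)C(CC(=O)O)c2ccc(Cl)c(F)c2)ccc1OCCN1C(=O)CCC1=O` has not yet been measured. It differs from compound 3 in one place: fluoro in place of hydrogen on an aromatic carbon. For the measured compounds named here, no pair of measured compounds differs by this change alone, so there is no measured step of this kind to lean on. With fluoro in place of hydrogen on an aromatic carbon, the step expected from compound 3 to compound 4 is a 1.1-fold lower number from compound 3 to compound 4 (0.05 log units; within the scatter), a change small enough to fall within the scatter and with no clear direction. On that basis compound 4 is expected to give about 30 nM in this assay, with a likely range from 12 nM to 80 nM.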

Compound 4, half-maximal inhibitory concentration in the C-X-C chemokine receptor type 3 assay: 70 nM
Beside the measured number, compound 4's estimate is 2.3-fold (0.37 log units) below it; the measured number falls inside the stated range.
By their numbers in the C-X-C chemokine receptor type 3 assay, from the lowest: compound 3; then compounds 2 and 4 (each within the scatter of the next); then compound 1.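

In the C-X-C chemokine receptor type 3 assay, compound 3 gives 34 nM and compound 4 gives 70 nM; putting fluoro in place of hydrogen, which turns the 4-chlorophenyl group into 4-chloro-3-fluorophenyl, gives a 2.1-fold higher number from compound 3 to compound 4 (0.31 log units; beyond the scatter), a modest step that shows inhibition at this receptor responds to even this single added atom on that ring. In a physicochemical assay for solubility, at pH 1.1 (on this read-out higher numbers stand for higher solubility and lower numbers for lower solubility), compound 3 gives 3000000 nM and compound 4 gives 3000000 nM; the same change gives no change at the digits printed from compound 3 to compound 4 (within the scatter), so the two read-outs do not move together for this one pair. Nothing measured here accounts for the step in receptor inhibition.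

The compounds shown leave open whether a methyl or a nitrile at this place would move the number in the same direction as fluoro, or the other way. Also open, going by these compounds, is whether fluoro here would give a similar step alongside the butyl chain of compound 2 or the trifluoropropyl chain of compound 1.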